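From Allyl to But-3-yn-1-yl on a Shared Core

The source may hold more compounds than are shown below. What is called first, only, known or untested is meant among the compounds shown, and "the series" means these compounds.

In a functional assay on HEp-2 cells (Homo sapiens) for inhibition, read by MTT assay, with a stated time of 72 h (on this read-out lower numbers stand for stronger inhibition and higher numbers for weaker inhibition), compound 1 `CC(C)O[C@@H]1C=CC(=O)[C@@H](CO)O1` gives 34900 nM and compound 2 `C#CCO[C@@H]1C=CC(=O)[C@@H](CO)O1` gives 15400 nM while compound 3 `C=CCO[C@@H]1C=CC(=O)[C@@H](CO)O1` gives 26100 nM on the same read-out. Compound 3 lies within the scatter of both others, as a 1.3-fold lower number from compound 1 to compound 3 (0.13 log units; within the scatter) and a 1.7-fold higher number from compound 2 to compound 3 (0.23 log units; within the scatter) show, although a 2.3-fold lower number from compound 1 to compound 2 (0.36 log units; beyond the scatter) goes beyond it. Compound 4 `C#CCCO[C@@H]1C=CC(=O)[C@@H](CO)O1` differs from compound 3 by propargyl in place of vinyl on a saturated chain carbon bound to an oxygen on a saturated carbon. The closest measured guide is a 1.7-fold higher number from compound 2 to compound 3 (0.23 log units; within the scatter) between a triple and a double bond, so no step beyond the scatter is expected in this assay for this change. The step expected is a 1.3-fold lower number from compound 3 to compound 4 (0.12 log units; within the scatter) by this estimate. Compound 4 is estimated at 20000 nM with an expected range from 10000 nM to 40000 nM overall.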

Compound 4, half-maximal inhibitory concentration: 7100 nM
For compound 4 the middle estimate is 2.8-fold (0.45 log units) above the measured one; measured number below the stated range.
By their numbers in this assay, from the lowest: compound 4; then compounds 2, 3 and 1 (each within the scatter of the next, the first and the last beyond it).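

Lengthening the chain on this oxygen while keeping its triple bond brings a gain the earlier compounds could not show, with a 2.2-fold lower number from compound 2 to compound 4 (0.34 log units; beyond the scatter). But-3-yn-1-yl also stands clear of the allyl chain, with a 3.7-fold lower number from compound 3 to compound 4 (0.57 log units; beyond the scatter), and of isopropyl, with a 4.9-fold lower number from compound 1 to compound 4 (0.69 log units; beyond the scatter). No measurement shown here explains these gains.

A plain butyl chain would help show whether chain length alone or the triple bond carries the gain. From the compounds shown here alone, whether a longer chain such as pent-4-yn-1-yl, or a chain bearing an amine, goes further remains open.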